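A few compounds are considered here, and "the series" means these few. Any claim that something is new, unique, unknown or untested is made for them only; others in the source may bear on it.

Working notes on the series. Two compounds share the core and differ only at one aromatic carbon. Compound 1 `CSc1ccccc1N1C(N)=NC(N)=NC1(C)C` carries methylsulfanyl there; in an assay for inhibition of Dihydrofolate reductase (Bos taurus), at pH 7.20 (on this read-out lower numbers stand for lower potency and higher numbers for higher potency (the scale is a negative logarithm)), compound 1 gives 3.91. Compound 2 `CCc1ccccc1N1C(N)=NC(N)=NC1(C)C` carries ethyl in the same place; in this assay compound 2 gives 4.48. For the measured compounds named here, the one measured step is a number 0.57 log units higher from compound 1 to compound 2 (beyond the scatter), so compound 2 stands highest of the two numbers, with compound 1 as the nearest and lower neighbour.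

The next compound is compound 3 `CC1(C)N=C(N)N=C(N)N1c1ccccc1O`. The change from compound 2 is hydroxy in place of ethyl on an aromatic carbon. No measured step swaps ethyl for hydroxy; the only step in hand, a number 0.57 log units higher from compound 1 to compound 2 (beyond the scatter), shows that ethyl sat higher than methylsulfanyl at this carbon, which gives a weak hint that a group other than ethyl here may fall back toward the level of compound 1, though the direction for hydroxy is not shown directly. On that basis a modest downward step is expected, a number 0.48 log units lower from compound 2 to compound 3 (beyond the scatter), with wide uncertainty. Compound 3 is estimated at 4, in the range 3.3 to 4.7, in this assay.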

Compound 3, logarithm of the reciprocal of the active concentration, log(1/C): 4.18
For compound 3 the middle estimate is 0.18 log units below the measured one, and the stated range covers the measured number.
By their numbers in this assay, from the lowest: compounds 1, 3 and 2 (each within the scatter of the next, the first and the last beyond it).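

In this assay, hydroxy on this aromatic carbon, ortho to a large group, cannot be told apart from either earlier group: the swap from ethyl gives a number 0.30 log units lower from compound 2 to compound 3 (within the scatter), and the swap from methylsulfanyl gives a number 0.27 log units higher from compound 1 to compound 3 (within the scatter). Both of these steps stay inside the scatter even though ethyl and methylsulfanyl are themselves separated by a number 0.57 log units higher from compound 1 to compound 2 (beyond the scatter), so compound 3 does not establish a third distinct level at this position. Hydroxy brings one hydrogen-bond donor and one hydrogen-bond acceptor where ethyl has none, yet this exchange gives no step beyond the scatter, and no evidence at hand bears on the reason for these numbers.

The compounds shown leave open whether an amine, a methoxy group or a longer chain such as propyl on this carbon would give a step beyond the scatter from compound 3. All three compounds differ at this one carbon, so they also leave open how changes elsewhere on the shared core would read.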